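Swapping Methoxy for Chloro: What Cytotoxicity Might Show

A few compounds are considered here, and "the series" means these few. Any claim that something is new, unique, unknown or untested is made for them only; others in the source may bear on it.

Within the data shown here, compound 2 `CCOC(=O)CCCCCOc1cccc(CN(C(=O)c2ccc(-c3cccc(OC)c3)cc2)C(C)C)c1` is one of two compounds measured in an ADME assay on HEK293 cells (Homo sapiens) for cytotoxicity, read by CellTiter-Glo and resazurin assay, with a stated time of 72 h; a lower number here means that less compound is needed, a higher number that more compound is needed for the effect. In this assay compound 2 gives only a limit, > 21000 nM, so no number for it is known. Compound 1 `CCOC(=O)CCCCCOc1cccc(CN(C(=O)c2ccc(-c3ccc4ccccc4c3)cc2)C(C)C)c1` likewise reaches only a limit in this assay, > 26000 nM. Among the measured compounds shown here, the one measured step, a step that the two limits leave unreadable from compound 1 to compound 2, is unreadable, since both of its ends sit at limits, the limit of > 21000 nM in this assay, at which 1 of the 2 values shown sits, and (the limit of > 26000 nM in this assay, at which 1 of the 2 values shown sits). Compound 3 `CCOC(=O)CCCCCOc1cccc(CN(C(=O)c2ccc(-c3cccc(Cl)c3)cc2)C(C)C)c1` differs from compound 2 in one place: chloro in place of methoxy on an aromatic carbon. For the measured compounds named here, no measured step speaks to this change, and the only step known gives no size at all. With both measured compounds at limits, no direction beyond the scatter can be read, and compound 3 is expected to sit at a limit as well. The estimate for compound 3 is therefore 30000 nM, between 10000 nM and 100000 nM. The step this implies, a step that the limit leaves unreadable from compound 2 to compound 3, is expected to be small.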

Compound 3, half-maximal effective concentration: > 18400 nM
Compound 3: a limit, no number (the forecaster's own chance of this, stated with the estimate: 80%); the middle value lies beyond the limit too.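

In this assay compound 3 gives > 18400 nM, a limit and not a number. With compound 1 and compound 2 also at limits, no step among these compounds can be read. The compounds shown leave open whether exchanging naphthalen-2-yl, 3-methoxyphenyl and 3-chlorophenyl changes cytotoxicity at all.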